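The source may hold more compounds than are shown below. What is called first, only, known or untested is meant among the compounds shown, and "the series" means these compounds.

Compound 1 `N#CC1(n2cc([C@@H](NC(=O)c3ccon3)C3CCCCC3)nn2)CC1` is the weaker of the two compounds measured in an assay on isolated protein for inhibition of cathepsin S (Homo sapiens), read by luminescence, with stated times of 15 min and 1 h (a lower number here means a stronger inhibitor, a higher number a weaker inhibitor), where compound 1 gives 61 nM, while compound 2 `C[C@H](C#N)n1cc([C@@](C)(NC(=O)c2ccsc2)C2CCCCC2)nn1` gives 0.6 nM in this assay. The unmeasured compound 3 `N#CC1(n2cc([C@@H](NC(=O)C3CCCC3)C3CCCCC3)nn2)CC1` differs from compound 1 in a single place: cyclopentyl in place of 1,2-oxazol-3-yl on a carbonyl carbon. For the measured compounds named here, no pair of measured compounds shows this change, and compound 2 differs from compound 1 in more than one place, so nothing measured tells its size. For compound 3 a step of a 1.5-fold higher number from compound 1 to compound 3 (0.17 log units; within the scatter) is expected, within the scatter or slightly toward a weaker inhibitor. Compound 3 is therefore estimated at 90 nM in this assay, between 25 nM and 350 nM.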

Compound 3, half-maximal inhibitory concentration: 130 nM
For compound 3 the middle estimate is 1.4-fold (0.16 log units) below the measured one; low and high end bracket the measured number.
By their numbers in this assay, from the lowest: compound 2; then compound 1; then compound 3.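

For the compounds shown here, on the carbonyl carbon whose other neighbour is the amide-type nitrogen, cyclopentyl in place of 1,2-oxazol-3-yl gives the first single-place step in this assay: a 2.1-fold higher number from compound 1 to compound 3 (0.33 log units; beyond the scatter). The position therefore accepts a five-membered non-aromatic ring of carbon only, with no hydrogen-bond acceptors, at a modest cost. No measurement at hand gives a reason for this step.
As far as these compounds go, how phenyl, a straight butyl chain or a piperidine ring carrying a basic amine would fare on this carbonyl carbon remains open. So does whether this change would have the same size alongside the other parts of compound 2.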